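This account rests on a few compounds, and the source may have more. Where it says the series, first, only, none or still open, it means among the compounds named here.

Compound 1 `O=C(NS(=O)(=O)c1ccc(F)cc1)c1cccnc1Cl` and compound 2 `O=C(NS(=O)(=O)c1ccc(Br)cc1)c1cccnc1Cl` share one core and differ by bromo in place of fluoro on an aromatic carbon. In a functional assay on MCF7 cells (Homo sapiens) for antiproliferative activity, read by MTT assay, with a stated time of 48 h (a higher number here means a weaker inhibitor, a lower number a stronger inhibitor), compound 1 gives 12500 nM, and compound 2 gives 11400 nM; this change made a 1.1-fold lower number from compound 1 to compound 2 (0.04 log units; within the scatter). Compound 3 `O=C(NS(=O)(=O)c1ccc(F)cc1)c1ccc(Cl)nc1` is built from the same atoms joined differently, and the difference between the two cores is not broken down here. In this assay compound 3 gives 16800 nM. Compound 4 `O=C(NS(=O)(=O)c1ccc(Br)cc1)c1ccc(Cl)nc1` has not yet been measured; it differs from compound 3 by bromo in place of fluoro on an aromatic carbon, the same change as before, since both place descriptions agree word for word. Compound 4 is therefore expected to sit close to compound 3, with an expected step of a 1.1-fold lower number from compound 3 to compound 4 (0.03 log units; within the scatter), because a 1.1-fold lower number from compound 1 to compound 2 (0.04 log units; within the scatter) stayed within the scatter. The estimate for compound 4 is 15500 nM, expected between 8000 nM and 30000 nM.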

Compound 4, half-maximal inhibitory concentration: 9050 nM
For compound 4 the middle estimate is 1.7-fold (0.23 log units) above the measured one; the measured number falls inside the stated range.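

Putting bromo in place of fluoro on the core of compound 3 gave a 1.9-fold lower number from compound 3 to compound 4 (0.27 log units; within the scatter) in this assay. Set beside the same change on the other core, the two steps cannot be told apart: the same change on two cores in this assay, a 1.1-fold lower number (0.04 log units; within the scatter) from compound 1 to compound 2 and a 1.9-fold lower number (0.27 log units; within the scatter) from compound 3 to compound 4, 1.7-fold (0.23 log units) apart, within the scatter of two such steps. This shows that the change behaved alike on these two cores, within the noise of the measurement, but both steps are small and two cores cannot speak for the whole series.

Only fluoro and bromo appear at this place on the aromatic ring. As far as these compounds go, whether an amine or a carboxylic acid there would shift the number beyond the scatter, and whether such a shift would carry between cores, remains open.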